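A few compounds are considered here, and "the series" means these few. Any claim that something is new, unique, unknown or untested is made for them only; others in the source may bear on it.

Measured so far:
compound 1, `CC(C)(O)CN1CCC(Oc2ccc([C@H]3CC[C@]4(CC3)OOC3(O4)C4CC5CC(C4)CC3C5)cc2)CC1`: 1810 nM
compound 2, `c1cc([C@H]2CC[C@]3(CC2)OOC2(O3)C3CC4CC(C3)CC2C4)ccc1OCC1CCNCC1`: 465 nM
compound 3, `c1cc([C@H]2CC[C@]3(CC2)OOC2(O3)C3CC4CC(C3)CC2C4)ccc1OCCC1CCNCC1`: 1190 nM

The read-out throughout is an ADME assay on the whole organism (strain FVB) for pharmacokinetics, with Mus musculus as the target, read by LC-MS, at a dose of 30 mg/kg by the oral route; on this read-out higher numbers stand for higher exposure at the dose given and lower numbers for lower exposure. Among the three measured compounds, compound 1 has the highest number; compound 3 is nearest to it, and the difference between the two is within the usual scatter, so no order can be claimed between them. Compound 2 is furthest away, and a 3.9-fold lower number from compound 1 to compound 2 (0.59 log units; beyond the scatter) lies beyond the scatter.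

The new compound is compound 4, `CC(C)(N)CCOc1ccc([C@H]2CC[C@]3(CC2)OOC2(O3)C3CC4CC(C3)CC2C4)cc1`. Relative to compound 1 the change is 3-amino-3-methylbutyl in place of 1-(2-hydroxy-2-methylpropyl)piperidin-4-yl on an oxygen on an aromatic ring. Within the data shown here, two measured steps bear on this. The step of a 3.9-fold lower number from compound 1 to compound 2 (0.59 log units; beyond the scatter) shows that taking away the 1-(2-hydroxy-2-methylpropyl) group while keeping a piperidine ring lowered exposure modestly, and the step of a 2.6-fold higher number from compound 2 to compound 3 (0.41 log units; beyond the scatter) shows that moving the ring one carbon further out raised it again. Compound 4 likewise gives up the hydroxyl-bearing group, but replaces the ring with a branched open chain for which no direct comparison exists. A modest drop, or none beyond the scatter, is therefore expected.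

The estimated step is a 2.0-fold lower number from compound 1 to compound 4 (0.30 log units; within the scatter), so compound 4 is expected to give about 900 nM, with a likely range from 350 nM to 2300 nM.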

Compound 4, maximal plasma concentration: 1050 nM
For compound 4 the middle estimate is 1.2-fold (0.07 log units) below the measured one, within the range that was stated.
By their numbers in this assay, from the lowest: compound 2; then compounds 4, 3 and 1 (each within the scatter of the next).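

In this assay, the open chain 3-amino-3-methylbutyl, with 6 heavy atoms and no ring, stands level with the 11-atom 1-(2-hydroxy-2-methylpropyl)piperidin-4-yl group on the oxygen of the aromatic ring, with a 1.7-fold lower number from compound 1 to compound 4 (0.24 log units; within the scatter), and level with the piperidine chain of compound 3, with a 1.1-fold lower number from compound 3 to compound 4 (0.05 log units; within the scatter). Among these compounds, then, neither a piperidine ring nor the hydroxyl-bearing group is needed to reach this level of exposure, and the open chain also clears compound 2, with a 2.3-fold higher number from compound 2 to compound 4 (0.35 log units; beyond the scatter), the only one of the new steps that lies beyond the scatter. No measurement shown here explains these results.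

Going by these compounds, the role of each part of the new chain remains open: a 3-hydroxy-3-methylbutyl chain would test the amine, and an unbranched aminobutyl chain would test the two methyl groups. this assay also records only a peak concentration at one oral dose, so how long the exposure to each compound lasts remains unknown.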